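Adding a Chloro Group Beside a Trifluoromethyl Substituent

A few compounds are considered here, and "the series" means these few. Any claim that something is new, unique, unknown or untested is made for them only; others in the source may bear on it.

Compound 3 `COc1cc(-c2nn(-c3cccc(NC(=O)Nc4cccc(C(F)(F)F)c4)c3)cc2-c2ccncc2)ccc1Cl` is one of three ureas sharing a common core. In a functional assay on NCI/ADR-RES cells (Homo sapiens) for inhibition, read by sulforhodamine B assay, with a stated time of 48 h (a higher number here means a weaker inhibitor of growth, a lower number a stronger inhibitor of growth), compound 3 gives 3640 nM, the lowest of the three numbers but within scatter of both neighbours: compound 2 `COc1cc(-c2nn(-c3cccc(NC(=O)Nc4ccc(Cl)c(Cl)c4)c3)cc2-c2ccncc2)ccc1Cl` gives 4670 nM and compound 1 `COc1cc(-c2nn(-c3cccc(NC(=O)Nc4cc(C(F)(F)F)cc(C(F)(F)F)c4)c3)cc2-c2ccncc2)ccc1Cl` gives 5180 nM. Compound 4 `COc1cc(-c2nn(-c3cccc(NC(=O)Nc4ccc(Cl)c(C(F)(F)F)c4)c3)cc2-c2ccncc2)ccc1Cl` differs from compound 3 by chloro in place of hydrogen on an aromatic carbon. Among the measured compounds shown here, two steps bear on this change: a 1.4-fold lower number from compound 1 to compound 3 (0.15 log units; within the scatter) and a 1.3-fold lower number from compound 2 to compound 3 (0.11 log units; within the scatter). Both halogen and trifluoromethyl variations on this phenyl ring left the numbers within scatter, so no step beyond the scatter is expected from compound 3 to compound 4 in this assay, a 1.1-fold higher number from compound 3 to compound 4 (0.04 log units; within the scatter). Compound 4 is therefore estimated at 4000 nM, with a range from 2000 nM to 8000 nM.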

Compound 4, concentration for total growth inhibition: 7990 nM
Beside the measured number, compound 4's estimate is 2.0-fold (0.30 log units) below it; measured number inside the range.
By their numbers in this assay, from the lowest: compounds 3, 2, 1 and 4 (each within the scatter of the next, the first and the last beyond it).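

In this assay, chloro on this aromatic carbon, ortho to a trifluoromethyl group and para to a large group, gives the first step beyond the scatter among these ureas: a 2.2-fold higher number from compound 3 to compound 4 (0.34 log units; beyond the scatter). The other new step, trifluoromethyl in place of chloro, stays within the scatter: a 1.7-fold higher number from compound 2 to compound 4 (0.23 log units; within the scatter), so the size of the change depends on which pair is read. Nothing available explains the step from hydrogen to chloro. Going by these compounds, it remains open whether fluoro, methyl, methoxy or an amine at this carbon would follow chloro or hydrogen.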